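A few compounds are considered here, and "the series" means these few. Any claim that something is new, unique, unknown or untested is made for them only; others in the source may bear on it.

Compound 1, with the structure `CON/C(=N\C1=NC(=O)C(=O)N1C(C)C)Nc1ccc(Cl)c(Cl)c1`, was studied in an in vitro ADME assay on microsomes from liver (Homo sapiens) for metabolic stability, read by LC-MS; on this read-out higher numbers stand for a longer-lived compound and lower numbers for a shorter-lived compound. In this assay compound 1 gives > 1 h, which is a limit of the assay rather than a number. Compound 2, `CC(C)N/C(=N\C1=NC(=O)C(=O)N1C(C)C)Nc1ccc(Cl)c(Cl)c1`, differs from compound 1 by an isopropyl in place of a methoxy on an amine nitrogen. In this assay compound 2 gives > 1 h, again a limit and not a number. The step that the two limits leave unreadable from compound 1 to compound 2 therefore cannot be read in size or direction; what the two values show is that both sit at the limit of > 1 h in this assay, at which 2 of the 2 values shown sit. Compound 3, `CC(C)N1C(=O)C(=O)N=C1/N=C(\NCC(C)(C)C)Nc1ccc(Cl)c(Cl)c1`, has not yet been measured. Its difference from compound 1 is neopentyl in place of methoxy on an amine nitrogen. Among the measured compounds shown here, only the step from compound 1 to compound 2 bears on this change; it too puts a carbon chain in place of the methoxy on an amine nitrogen, and it is unreadable. No step beyond the scatter is therefore expected in this assay, and the estimated step is a step that the limit leaves unreadable from compound 1 to compound 3. Compound 3 is estimated at 1.5 h, with a range from 0.7 h to 4 h, and is expected most likely to be reported again only as a limit.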

Compound 3, half-life: > 1 h
Compound 3: only a limit was reported; the forecaster's own chance of this, stated with the estimate: 70%; the middle value lies beyond the limit too.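

No new step can be read among compound 1, compound 2 and compound 3 in this assay, because each is reported only as a limit of the assay: the limit of > 1 h in this assay, at which 3 of the 3 values shown sit. The compounds shown leave open what the actual half-life of each is, and whether methoxy, isopropyl and neopentyl on this amine nitrogen differ at all in this assay.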